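From Methyl to Trifluoromethyl on an Aromatic Carbon

A few compounds are considered here, and "the series" means these few. Any claim that something is new, unique, unknown or untested is made for them only; others in the source may bear on it.

- Compound 1 `O=C1C(Nc2ccccc2)=CC(=O)c2c1nc1n2[C@H]2OC[C@@H](O)[C@H]2OC1`: 1830 nM
- Compound 2 `CCc1ccc(NC2=CC(=O)c3c(nc4n3[C@H]3OC[C@@H](O)[C@H]3OC4)C2=O)cc1`: 1110 nM
- Compound 3 `Cc1ccc(NC2=CC(=O)c3c(nc4n3[C@H]3OC[C@@H](O)[C@H]3OC4)C2=O)cc1`: 1550 nM

These three compounds were tested in a functional assay on MGC-803 cells (Homo sapiens) for inhibition, read by sulforhodamine B assay; on this read-out lower numbers stand for stronger inhibition and higher numbers for weaker inhibition. At 1550 nM, compound 3 cannot be separated from either of the other two, since all three numbers lie within the usual scatter of one another.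

The next compound to be considered is compound 4 `O=C1C(Nc2ccc(C(F)(F)F)cc2)=CC(=O)c2c1nc1n2[C@H]2OC[C@@H](O)[C@H]2OC1`, which has trifluoromethyl in place of methyl on an aromatic carbon. For the measured compounds named here, no measured compound carries trifluoromethyl, so the data hold no direct precedent for this group.

The nearest evidence comes from the small alkyl changes on an aromatic carbon. There is a 1.2-fold lower number from compound 1 to compound 3 (0.07 log units; within the scatter) for methyl in place of hydrogen, and a 1.6-fold lower number from compound 1 to compound 2 (0.22 log units; within the scatter) for ethyl in place of hydrogen. Shortening ethyl to methyl gives a 1.4-fold higher number from compound 2 to compound 3 (0.15 log units; within the scatter). Each of these steps stays within the scatter, so this part of the structure has not yet shown a clear effect on the read-out.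

On that limited basis, no step beyond the scatter is expected, and no direction can be favoured with confidence. The expected result is a 1.1-fold lower number from compound 3 to compound 4 (0.04 log units; within the scatter). For compound 4 the estimated value is 1400 nM, with an expected range from 650 nM to 3000 nM.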

Compound 4, half-maximal inhibitory concentration: 1860 nM
Beside the measured number, compound 4's estimate is 1.3-fold (0.12 log units) below it, and the stated range covers the measured number.
By their numbers in this assay, from the lowest: compounds 2, 3, 1 and 4 (each within the scatter of the next).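

In this assay the change to trifluoromethyl, on an aromatic carbon para to a large group, gives no step beyond the scatter against any earlier compound: there is a 1.2-fold higher number from compound 3 to compound 4 (0.08 log units; within the scatter) and a 1.7-fold higher number from compound 2 to compound 4 (0.22 log units; within the scatter) as well as a 1.0-fold higher number from compound 1 to compound 4 (0.01 log units; within the scatter) in the comparison with the unsubstituted phenyl compound. The earlier compounds shown here had tested only hydrogen, methyl and ethyl at this place, so the finding that these numbers cannot be separated now extends to a group of four heavy atoms that carries fluorine, and all four compounds remain within the scatter of one another at this place. The data shown offer no explanation for why the read-out does not separate these groups.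

Going by these compounds, it remains open whether any group at this place can move the number beyond the scatter at all, for example an amine, a carboxylic acid, a methoxy group or a longer alkyl chain. The compounds shown also leave open whether this insensitivity holds when the same groups are combined with a change elsewhere on the shared core.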